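From bromo to allyl on an aromatic carbon

The source may hold more compounds than are shown below. What is called first, only, known or untested is meant among the compounds shown, and "the series" means these compounds.

Measured so far in a functional assay on BV-2 cells (Mus musculus) for inhibition, read by Griess assay, with a stated time of 24 h; on this read-out lower numbers stand for stronger inhibition and higher numbers for weaker inhibition:
- Compound 1 `C=CCc1ccc(OC)c(-c2cc(CCC)on2)c1`: > 200000 nM, a limit of the assay
- Compound 2 `C=CCOCc1cc(-c2cc(Br)ccc2OC)no1`: 90400 nM

For the measured compounds named here, only two compounds have been measured, and they give little to work from. In this assay, going by the values given here, compound 2 gives 90400 nM, the only actual number available so far. Compound 1 reached only a limit of the assay, > 200000 nM.

The next compound to be tested is compound 3 `C=CCOCc1cc(-c2cc(CC=C)ccc2OC)no1`. It departs from compound 2 at a single place: allyl in place of bromo on an aromatic carbon. The new allyl group sits para to a methoxy group and meta to a large group.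

Among the compounds with values here, no pair of measured compounds differs in just one place, so no measured step gives a size for this change. In this assay no shift beyond the usual scatter is therefore expected, and neither direction is favoured. The expected change, a 1.1-fold lower number from compound 2 to compound 3 (0.05 log units; within the scatter), is an estimate made with little support. For compound 3 the estimated value is 80000 nM, with an expected range from 30000 nM to 200000 nM.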

Compound 3, half-maximal inhibitory concentration: 28700 nM
Compound 3: middle estimate off by 2.8-fold (0.45 log units), on the high side, and the stated range ends above it.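

In this assay, allyl in place of bromo on this aromatic carbon, meta to a large group and para to a methoxy group, gives a 3.1-fold lower number from compound 2 to compound 3 (0.50 log units; beyond the scatter). For the compounds shown here, this is the first measured sign that the position responds to a change of group, and it shows that exchanging a single bromine for the 3 carbon atoms of allyl does not cost activity here. The second step, with allyloxy in place of ethyl on a saturated chain carbon bound to an aromatic carbon, gives an at least 6.9-fold lower number from compound 1 to compound 3 (0.84 log units; beyond the scatter), though its true size stays unfixed since compound 1 stands at a limit of the assay: the limit of > 200000 nM in this assay, at which 1 of the 3 values shown sits.

What the compounds shown leave open is whether the double bond of allyl matters or a saturated propyl group would read the same on this aromatic carbon, and how an amine, a carboxylic acid or a longer chain would read there. Going by these compounds, each change is also seen only once, so it remains open whether the step from bromo to allyl would keep its direction and size with a different group on the other side of the core.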